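This account rests on a few compounds, and the source may have more. Where it says the series, first, only, none or still open, it means among the compounds named here.

Measured compounds:
- compound 1, `O=C(NCc1ccc(F)cc1)c1ncc2cccnc2c1O`; in an ADME assay on a cell-free system (plasma, Homo sapiens) for protein binding, at pH 7.4, compound 1 gives 99.2%
- compound 2, `CCN1CC(c2nc(C(=O)NCc3ccc(F)cc3)c(O)c3ncccc23)CC1=O`; in this assay compound 2 gives 98.9%

Among the measured compounds shown here, compound 2 has the highest unbound fraction of the two measured values, but its nearest neighbour is compound 1, and the only measured step, a 1.4-fold higher unbound fraction from compound 1 to compound 2 (0.14 log units; within the scatter), is within the scatter, so the two compounds cannot be ranked against each other on these numbers.

Compound 3, `CN1CC(c2nc(C(=O)NCc3ccc(F)cc3)c(O)c3ncccc23)CC1=O`, is the next compound to be measured in this assay. It differs from compound 2 in one place: hydrogen in place of methyl on a saturated chain carbon bound to an amide-type nitrogen in a ring. For the measured compounds named here, no measured pair in this set shows this ethyl to methyl change, so the only step that bears on it is the one from compound 1 to compound 2, which added the whole 1-ethyl-5-oxopyrrolidin-3-yl group and still stayed within the scatter. A loss of a single carbon on that same group is expected to move the unbound fraction even less, and no step beyond the scatter is expected for no change at the digits printed from compound 2 to compound 3 (within the scatter) in either direction. Compound 3 is therefore estimated at 98.9% in this assay, with a range from 98% to 99.4%.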

Compound 3, plasma protein binding in the plasma assay: 98.8%
Compound 3: middle estimate off by 1.1-fold (0.04 log units) (unbound fraction), on the low side; measured number inside the range.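

In the plasma assay, the change from ethyl to methyl on a saturated chain carbon bound to an amide-type nitrogen in a ring gives a 1.1-fold higher unbound fraction from compound 2 to compound 3 (0.04 log units; within the scatter), and adding the whole 1-methyl-5-oxopyrrolidin-3-yl group gives a 1.5-fold higher unbound fraction from compound 1 to compound 3 (0.18 log units; within the scatter), so neither the shorter chain nor the whole group separates these compounds on plasma protein binding. In a physicochemical assay for lipophilicity, at pH 7.4 (on this read-out lower numbers stand for lower lipophilicity and higher numbers for higher lipophilicity), compound 2 gives 2.7 and compound 3 gives 2.3, which shows that the same ethyl to methyl change does lower lipophilicity: the measured partition coefficient of compound 2, 2.7, and of compound 3, 2.3, a number 0.40 log units lower (beyond the scatter). Among the compounds shown here, for this one pair, then, a step beyond the scatter in the physicochemical assay comes with no readable step in the plasma assay, which the earlier compounds alone could not show.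

As far as these compounds go, one pair sets no trend, and it remains open whether a longer chain such as butyl in place of the ethyl would also stay within the scatter in the plasma assay. From the compounds shown here alone, it is equally open whether a group of another kind at this place, such as an amine or a carboxylic acid, would free more of the compound from plasma protein.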